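Methyl added at the branch carbon of a phenylurea series

The source may hold more compounds than are shown below. What is called first, only, known or untested is meant among the compounds shown, and "the series" means these compounds.

Three ureas have been measured in an ADME assay on the whole organism with Oryza sativa as the target, tested at 1 uM; a lower number here means a stronger effect, a higher number a weaker effect of the compound at the concentration tested. Compound 1 `CCc1cccc(NC(=O)N[C@H](C)c2ccccc2)c1` gives 71%, and compound 3 `CC(C)c1cccc(NC(=O)N[C@H](C)c2ccccc2)c1` gives 61%. The change between them, (methyl in place of hydrogen on a saturated chain carbon bound to an aromatic carbon and a saturated chain carbon), produced a number 10 percentage points lower from compound 1 to compound 3 (within the scatter). Compound 2 `CC(C)c1ccccc1NC(=O)N[C@H](C)c1ccccc1` gives 101%, the highest of the three; the difference between the core of compound 2 and the core of compound 1 is not broken down here.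

Compound 4 `C[C@@H](NC(=O)Nc1ccccc1C(C)(C)C)c1ccccc1` has not yet been measured. It differs from compound 2 by methyl in place of hydrogen on a saturated chain carbon bound to an aromatic carbon and two saturated chain carbons. Within the data shown here, this is the same kind of change as the one from compound 1 to compound 3, but the place is not identical: there the carbon carried one saturated chain carbon, here it carries two saturated chain carbons.

Because a number 10 percentage points lower from compound 1 to compound 3 (within the scatter) stayed within the scatter, the step from compound 2 to compound 4 in this assay is expected to be small as well, a number 6 percentage points lower from compound 2 to compound 4 (within the scatter). On that basis compound 4 is estimated at 95%, with an expected range from 75% to 112%.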

Compound 4, a percentage reported as activity, at one concentration (the size of the read-out at that concentration, not a potency): 95%
The estimate for compound 4 equals the measured number at the digits printed; the measured number falls inside the stated range.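

In this assay the added methyl, isopropyl to tert-butyl, gave a number 6 percentage points lower from compound 2 to compound 4 (within the scatter) on the core of compound 2. Set beside the earlier step, the change reads alike on the two cores: the same change on two cores in this assay, a number 10 percentage points lower (within the scatter) from compound 1 to compound 3 and a number 6 percentage points lower (within the scatter) from compound 2 to compound 4, 4 percentage points apart, within the scatter of two such steps. This shows that the change carried from one core to the other as a step within the scatter, but it does not show that the methyl has a real effect on either core, nor that the step would stay as small on any other core in the series.

The compounds shown leave open how the read-out responds when something other than methyl enters at this saturated chain carbon, such as a hydroxyl, an amine or a fluorine. They also leave open whether a longer chain in place of the isopropyl or tert-butyl would keep the read-out where it stands or move it beyond the scatter.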